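This account rests on a few compounds, and the source may have more. Where it says the series, first, only, none or still open, it means among the compounds named here.

Measured in a functional assay on MDA-MB-231 cells (Homo sapiens) for antiproliferative activity, read by luminescence, with a stated time of 72 h; on this read-out lower numbers stand for stronger inhibition and higher numbers for weaker inhibition:
- compound 1 `Oc1ccc(Cn2cccn2)c2cccnc12`: 3600 nM
- compound 2 `O=C1c2ccccc2C(=O)N1CCCOc1ccc(Cn2ccnc2)c2cccnc12`: "not determined" (no result reported)
- compound 3 `CC(C)(C)OC(=O)Oc1ccc(Cn2ccnc2)c2cccnc12`: 31500 nM

Compound 3 holds the higher of the two numbers in this assay, and the gap down to compound 1 lies beyond the scatter. Compound 2 adds no number.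

The next compound is compound 4 `CC(C)(CCl)C(=O)Oc1ccc(Cn2ccnc2)c2cccnc12`, with 1-(chloromethyl)-1-methylethyl in place of tert-butoxy on a carbonyl carbon. Among the measured compounds shown here, no measured pair differs in one place, so the size of this step remains a judgement. Compound 3 at 31500 nM sits at the weak end, and compound 1 shows a lower number at 3600 nM. A modest move towards a lower number is expected, estimated as a 2.6-fold lower number from compound 3 to compound 4 (0.42 log units; beyond the scatter). For compound 4 the estimated value is 12000 nM, with an expected range of 3500 nM to 35000 nM.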

Compound 4, half-maximal inhibitory concentration: 12400 nM
For compound 4 the middle estimate is 1.0-fold (0.01 log units) below the measured one, and the stated range covers the measured number.
By their numbers in this assay, from the lowest: compound 1; then compound 4; then compound 3.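

In this assay, among the compounds shown here, 1-(chloromethyl)-1-methylethyl in place of tert-butoxy on a carbonyl carbon gives a 2.5-fold lower number from compound 3 to compound 4 (0.40 log units; beyond the scatter) and provides the first single-place comparison. Both groups count 5 heavy atoms, so the modest step comes with a swap of oxygen for chlorine and the loss of one hydrogen-bond acceptor, at no change in size by that count. No measurement shown here explains the step. Whether the chlorine or the carbon that replaces oxygen accounts for the difference stays open. A plain tert-butyl group or a dimethylamino group on the same carbonyl carbon would help separate the two.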